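Chalcone oxyacetamide series: aryl variation at the enone

This account rests on a few compounds, and the source may have more. Where it says the series, first, only, none or still open, it means among the compounds named here.

Of the compounds shown here, two of the shared core have been measured in a functional assay on MCF7 cells (Homo sapiens) for antiproliferative activity, read by MTT assay, with a stated time of 72 h; a higher number here means a weaker inhibitor, a lower number a stronger inhibitor. Compound 1 `O=C(COc1ccc(C(=O)/C=C/c2ccc(Cl)cc2Cl)cc1)N[C@H]1CCOC1=O` gives 34400 nM. Compound 2 `CC(C)c1ccc(/C=C/C(=O)c2ccc(OCC(=O)N[C@H]3CCOC3=O)cc2)cc1` gives 23400 nM. Among the compounds with values here, the one step between them, a 1.5-fold lower number from compound 1 to compound 2 (0.17 log units; within the scatter), is the only structural comparison available. On these two numbers compound 2 has the lower value, but the gap to compound 1 is within the scatter, so no order between them is claimed.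

Compound 3 `O=C(COc1ccc(C(=O)/C=C/c2cccc(F)c2)cc1)N[C@H]1CCOC1=O` is not yet measured in this assay . It differs from compound 2 by 3-fluorophenyl in place of 4-isopropylphenyl on a double-bonded chain carbon bound to a double-bonded chain carbon. Within the data shown here, the only measured step that bears on this change is the aryl exchange from compound 1 to compound 2, which stayed within the scatter, and it does not involve a fluorophenyl group, so the present change is untested. Given that one aryl exchange left this assay unchanged, no step beyond the scatter is expected for compound 3, in either direction. The estimated step is a 1.2-fold higher number from compound 2 to compound 3 (0.08 log units; within the scatter). Compound 3 is expected to give about 28000 nM, with a range from 9000 nM to 85000 nM.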

Compound 3, half-maximal inhibitory concentration: > 64000 nM
Compound 3 ended at the assay's limit; the forecaster's own chance of this, stated with the estimate: 10%; middle value at least 2.2-fold (0.35 log units) from the limit.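

Within the data shown here, the aryl group on a double-bonded chain carbon bound to a double-bonded chain carbon is not indifferent in this assay: 3-fluorophenyl in place of 4-isopropylphenyl gives an at least 2.7-fold higher number from compound 2 to compound 3 (0.43 log units; beyond the scatter), the first step at this place beyond the scatter. Set against 2,4-dichlorophenyl, the same 3-fluorophenyl group gives an at least 1.8-fold higher number from compound 1 to compound 3 (0.26 log units; that floor lies within the scatter), so no order is read from that pair. The value of compound 3 is a limit and not a number, which makes both steps floors whose full size stays unknown: the limit of > 64000 nM in this assay, at which 1 of the 3 values shown sits.

The exchange of 4-isopropylphenyl for 3-fluorophenyl replaces the whole aryl group, so the share of the isopropyl group's loss and the share of the fluorine's arrival cannot be separated on these compounds. Also open, going by these compounds, is how this place responds to a phenyl group carrying an amine or a carboxylic acid, or to a longer alkyl chain in place of the isopropyl group.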